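The source may hold more compounds than are shown below. What is called first, only, known or untested is meant among the compounds shown, and "the series" means these compounds.

Measured so far in a functional assay on MCF7 cells (Homo sapiens) for antiproliferative activity; on this read-out higher numbers stand for weaker inhibition and lower numbers for stronger inhibition:
- compound 1 `COc1ccc(/C=C/C(=O)c2ccc(OCCn3cc(CN4C(=O)/C=C/C(C)(C)C/C=C(\C)CC/C=C/4C)nn3)cc2O)cc1`: 2.85 ug/mL
- compound 2 `COc1ccccc1/C=C/C(=O)c1ccc(OCCn2cc(CN3C(=O)/C=C/C(C)(C)C/C=C(\C)CC/C=C/3C)nn2)cc1O`: 1.17 ug/mL
- compound 3 `COc1cc(/C=C/C(=O)c2ccc(OCCn3cc(CN4C(=O)/C=C/C(C)(C)C/C=C(\C)CC/C=C/4C)nn3)cc2O)cc(OC)c1OC`: 2.78 ug/mL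

Compound 2 holds the lowest number of the three in this assay, set apart from both others. The steps are a 2.4-fold lower number from compound 1 to compound 2 (0.39 log units; beyond the scatter), a 2.4-fold higher number from compound 2 to compound 3 (0.38 log units; beyond the scatter) and a 1.0-fold lower number from compound 1 to compound 3 (0.01 log units; within the scatter).

Compound 4 `C/C1=C\CC(C)(C)/C=C/C(=O)N(Cc2cn(CCOc3ccc(C(=O)/C=C/c4ccc(C)cc4)c(O)c3)nn2)/C(C)=C/CC1` differs from compound 2 by 4-methylphenyl in place of 2-methoxyphenyl on a double-bonded chain carbon bound to a double-bonded chain carbon. Each measured step keeps a methoxy-bearing ring, so none bears directly on this change; they only show that moving the ring substitution away from the arrangement of compound 2 costs a modest amount in this assay. The expected step of a 1.9-fold higher number from compound 2 to compound 4 (0.27 log units; within the scatter) is therefore modest and upward, with none beyond the scatter also possible. Compound 4 is estimated at 2.2 ug/mL, between 1 ug/mL and 4.8 ug/mL.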

Compound 4, half-maximal inhibitory concentration: 1.21 ug/mL
Estimate against measurement, compound 4: 1.8-fold (0.26 log units) above; low and high end bracket the measured number.
By their numbers in this assay, from the lowest: compounds 2 and 4 (each within the scatter of the next); then compounds 3 and 1 (each within the scatter of the next).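

A methoxy group on this ring is not needed for the low number in this assay: 4-methylphenyl in place of 2-methoxyphenyl leaves the value within the scatter (a 1.0-fold higher number from compound 2 to compound 4 (0.01 log units; within the scatter)). With the substituent name kept at 4, methyl in place of methoxy on an aromatic carbon gives a modest step (a 2.4-fold lower number from compound 1 to compound 4 (0.37 log units; beyond the scatter)), and 4-methylphenyl in place of 3,4,5-trimethoxyphenyl gives a similar one (a 2.3-fold lower number from compound 3 to compound 4 (0.36 log units; beyond the scatter)). Nothing shown explains these steps.

Open, as far as these compounds go, is how unsubstituted phenyl, 2-methylphenyl or a ring bearing an amine or a carboxylic acid would read at this place.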